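This account rests on a few compounds, and the source may have more. Where it says the series, first, only, none or still open, it means among the compounds named here.

Working notes on a small series of vinyl and pyrrole bis-sulfones carrying a thiazoline-methyl sulfone arm, all read in a functional assay for inhibition, tested at 100 uM; on this read-out higher numbers stand for more inhibition at the one concentration tested (going by the name of the read-out) and lower numbers for less inhibition.

Compound 2 `O=S(=O)(/C=C/S(=O)(=O)c1ccccc1)CC1=NCCS1` gives 30.4% in this assay. Compound 1 `Cc1ccc(S(=O)(=O)/C=C/S(=O)(=O)CC2=NCCS2)cc1` carries the change methyl in place of hydrogen on an aromatic carbon relative to compound 2. In this assay compound 1 gives 21.7%. The step of a number 8.7 percentage points lower from compound 2 to compound 1 (within the scatter) is small and within the scatter. Compound 3 `O=S(=O)(CC1=NCCS1)c1c[nH]cc1S(=O)(=O)c1ccccc1` has a different core from compound 2; how the two cores differ is not broken down here. In this assay compound 3 gives 34.6%, which stands near the value of compound 2 within the scatter, while the gap to compound 1 lies beyond it.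

Compound 4 `Cc1ccc(S(=O)(=O)c2c[nH]cc2S(=O)(=O)CC2=NCCS2)cc1` is not yet measured. It differs from compound 3 by methyl in place of hydrogen on an aromatic carbon, the same change that separates compound 2 from compound 1, at the same place on the ring. On the measured pair this change moved the read-out by a number 8.7 percentage points lower from compound 2 to compound 1 (within the scatter), within the scatter, so a step of about a number 6.6 percentage points lower from compound 3 to compound 4 (within the scatter) is expected from compound 3 to compound 4, resting only on that one measured pair. For compound 4 the estimate in this assay is 28%, with a range of 15% to 41% expected.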

Compound 4, a percentage reported as inhibition, at one concentration (the size of the read-out at that concentration, not a potency): 23.7%
Beside the measured number, compound 4's estimate is 4.3 percentage points above it; the measured number falls inside the stated range.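

In this assay the change from phenyl to 4-methylphenyl gives a number 10.9 percentage points lower from compound 3 to compound 4 (beyond the scatter) on the core of compound 3, a modest step. Set beside the step on the core of compound 2, the change carries across these two cores without a difference that can be told apart from the scatter: the same change on two cores in this assay, a number 8.7 percentage points lower (within the scatter) from compound 2 to compound 1 and a number 10.9 percentage points lower (beyond the scatter) from compound 3 to compound 4, 2.2 percentage points apart, within the scatter of two such steps. For the compounds shown here, this does not show a general rule, since it rests on two pairs, two cores and one change at one concentration, and only the step on the core of compound 3 lies beyond the scatter, so the agreement says nothing about other cores or about why the read-out moves.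

All compounds shown carry either hydrogen or methyl at the position para to the large group, which leaves open how a chlorine atom, a methoxy group, an amine or a carboxylic acid would read there on either core. On these data alone, the thiazoline-methyl sulfone arm is also common to all of them, so it remains open whether a longer chain in that arm would alter the read-out or the size of the methyl step.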